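A few compounds are considered here, and "the series" means these few. Any claim that something is new, unique, unknown or untested is made for them only; others in the source may bear on it.

Compound 1, `CO[C@H]1CC[C@H](Nc2cc(NCc3cnccc3C(F)(F)F)ncc2C#N)CC1`, gives 1100 nM in an assay on isolated protein for inhibition of protein kinase C theta type (Homo sapiens), read by TR-FRET, with a stated time of 2 h; a lower number here means a stronger inhibitor, a higher number a weaker inhibitor. Compound 2, `N#Cc1cnc(NCc2cnccc2C(F)(F)F)cc1NCC1CCOCC1`, gives 400 nM. Compound 3, `CNC(=O)[C@H]1CC[C@@H](Nc2cc(NCc3cnccc3C(F)(F)F)ncc2C#N)CC1`, gives 27 nM.

Compound 3 has the lowest number of the three: the steps of a 41-fold lower number from compound 1 to compound 3 (1.61 log units; beyond the scatter) and a 15-fold lower number from compound 2 to compound 3 (1.17 log units; beyond the scatter) are both large, and a 2.8-fold lower number from compound 1 to compound 2 (0.44 log units; beyond the scatter) is modest. Compound 4, `CC1(C)[C@@H](Nc2cc(NCc3cnccc3C(F)(F)F)ncc2C#N)C[C@H]1C(N)=O`, differs from compound 3 by a single change: 3-carbamoyl-2,2-dimethylcyclobutyl in place of 4-(methylcarbamoyl)cyclohexyl on a nitrogen on an aromatic ring. Among the measured compounds shown here, the two large steps into compound 3 show that a carbamoyl-bearing ring on that nitrogen goes with strong inhibition, and compound 4 keeps an amide on a smaller ring; no measured pair tests a ring-size change directly. A step of a 2.2-fold higher number from compound 3 to compound 4 (0.35 log units; beyond the scatter) is therefore expected, most likely a small loss. Compound 4 is estimated at 60 nM, within 15 nM to 250 nM.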

Compound 4, half-maximal inhibitory concentration: 140 nM
Beside the measured number, compound 4's estimate is 2.3-fold (0.37 log units) below it, within the range that was stated.
By their numbers in this assay, from the lowest: compound 3; then compound 4; then compound 2; then compound 1.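

The amide survives a large change to the ring on this nitrogen, though at a cost (a 5.2-fold higher number from compound 3 to compound 4 (0.71 log units; beyond the scatter)). Even so, the 3-carbamoyl-2,2-dimethylcyclobutyl group still beats both groups without an amide (a 2.9-fold lower number from compound 2 to compound 4 (0.46 log units; beyond the scatter); a 7.9-fold lower number from compound 1 to compound 4 (0.90 log units; beyond the scatter)), so the two amide compounds, compound 3 and compound 4, hold the lowest numbers of the four. Nothing available explains the loss on moving to the smaller ring.

Ring size, the two ring methyl groups and the amide's methyl all change together, so their separate shares remain unknown. A 4-carbamoylcyclohexyl group would help to separate them, and a carboxylic acid in place of the amide would test whether the amide itself is needed.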